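The compounds below may be only part of what the source reports. "The series", "measured", "known", "first", "only" and "open" are said of these compounds alone.

In an ADME assay on MDA-MB-435 cells (Homo sapiens) for cytotoxicity (on this read-out higher numbers stand for lower toxicity in this test and lower numbers for higher toxicity in this test), compound 1 `Cc1ccc(-n2c(SCC(=O)NNC(=O)c3ccccc3O)nnc2-c2ccccc2O)cc1` reaches only a limit of the assay, > 20000 nM. Compound 2 `COc1ccccc1-n1c(SCC(=O)NNC(=O)c2ccccc2O)nnc1-c1ccccc1O` likewise reaches only a limit in this assay, > 20000 nM. The step between them, a step that the two limits leave unreadable from compound 1 to compound 2, therefore cannot be read. Both results sit at the same limit, as the limit of > 20000 nM in this assay, at which 2 of the 2 values shown sit, shows, so compound 2 stands at the edge of what this assay can report, with no numbered result among the measured compounds. Compound 3 `O=C(CSc1nnc(-c2ccccc2O)n1Cc1ccccc1)NNC(=O)c1ccccc1O` is the unmeasured one; it carries benzyl in place of 2-methoxyphenyl on an aromatic nitrogen, the benzyl standing on the aromatic nitrogen of a five-membered aromatic ring with 3 nitrogen. With no readable measured step, neither a direction nor a size for this change in this assay can be drawn from the measured pair. The expectation is that compound 3 will again sit at the limit, estimated at 30000 nM with a range of 10000 nM to 100000 nM. That expected step, a step that the limit leaves unreadable from compound 2 to compound 3, is an estimate without a measured basis.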

Compound 3, half-maximal cytotoxic concentration: > 20000 nM
Compound 3 ended at the assay's limit; the forecaster's own chance of this, stated with the estimate: 85%; the middle value is on the limit's open side.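

The steps linking compound 3 to compound 1 and compound 2 cannot be read, because all three results are only limits: the limit of > 20000 nM in this assay, at which 3 of the 3 values shown sit. The compounds shown leave open whether any group on that aromatic nitrogen changes the result in this assay at all.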